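The source may hold more compounds than are shown below. What is called first, only, known or untested is meant among the compounds shown, and "the series" means these compounds.

Measured so far:
compound 1, `CC(=O)N[C@@H](C)C(=O)N(C)/N=N/c1ccc(Br)cc1`: 25.5 h
compound 2, `CC(=O)N[C@H](C(=O)N(C)/N=N/c1ccc(C#N)cc1)C(C)C`: 84.3 h

In a physicochemical assay for metabolic stability, read by HPLC, in phosphate buffer, at pH 7.7 (on this read-out lower numbers stand for a shorter-lived compound and higher numbers for a longer-lived compound), compound 2 gives 84.3 h, the highest of the two numbers; the nearest is compound 1 with 25.5 h, a gap beyond the scatter. Compound 3, `CC(=O)N[C@@H](C)C(=O)N(C)/N=N/c1ccc(C#N)cc1`, differs from compound 2 by methyl in place of isopropyl on a saturated chain carbon bound to an amide-type nitrogen and a carbonyl carbon. Within the data shown here, no step between measured compounds isolates this change, and compound 1 and compound 2 differ in two places, so their values cannot be parted. A downward step of moderate size, beyond the scatter, is expected, a 1.9-fold lower number from compound 2 to compound 3 (0.27 log units; within the scatter). Compound 3 is estimated at 45 h, with a range of 20 h to 100 h.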

Compound 3, half-life: 9.8 h
Compound 3: middle estimate off by 4.6-fold (0.66 log units), on the high side; the whole stated range lies above it.
By their numbers in this assay, from the lowest: compound 3; then compound 1; then compound 2.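

In this assay, the change to methyl from isopropyl, on a saturated chain carbon bound to an amide-type nitrogen and a carbonyl carbon, now has its own step (an 8.6-fold lower number from compound 2 to compound 3 (0.93 log units; beyond the scatter)), which shows that the half-life responds to this position. The aromatic carbon responds too, with cyano in place of bromo on the shared core (a 2.6-fold lower number from compound 1 to compound 3 (0.42 log units; beyond the scatter)). No measured evidence accounts for either step. On these data alone, whether a longer chain or an amine on that chain carbon would follow the same direction remains open. So does whether isopropyl gives a similar step with bromo on the aromatic carbon.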